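The compounds below may be only part of what the source reports. "The series", "measured", "known", "first", "only" and "open" are said of these compounds alone.

Compounds measured so far:
- compound 1 `Cc1ccc(OCC(=O)NNC(=O)c2cc3ccccc3oc2=O)c(C(=O)c2cccc(Cl)c2)c1`: 67300 nM
- compound 2 `Cc1ccc(OCC(=O)NNC(=O)c2cc3ccccc3oc2=O)c(C(=O)c2ccccc2)c1`: 86500 nM
- compound 3 `Cc1ccc(OCC(=O)NNC(=O)c2cc3ccccc3oc2=O)c(C(=O)c2ccccc2Cl)c1`: 48400 nM

In a functional assay on Ehrlich cells (Mus musculus) for cytotoxicity, read by trypan blue exclusion, with a stated time of 48 h (on this read-out lower numbers stand for stronger inhibition and higher numbers for weaker inhibition), compound 1 sits within the scatter of both other compounds, so no ranking among the three can be read from these numbers. Compound 4 `Cc1ccc(OCC(=O)NNC(=O)c2cc3ccccc3oc2=O)c(C(=O)c2ccc(Cl)cc2)c1` differs from compound 1 by 4-chlorophenyl in place of 3-chlorophenyl on a carbonyl carbon. Going by the values given here, two measured steps concern the same part of the shared core: a 1.3-fold higher number from compound 1 to compound 2 (0.11 log units; within the scatter) and a 1.4-fold lower number from compound 1 to compound 3 (0.14 log units; within the scatter); the third, a 1.8-fold lower number from compound 2 to compound 3 (0.25 log units; within the scatter), is also within the scatter. Moving the chloro around that ring, or removing it, has not shifted the number beyond the scatter. For compound 4 no step beyond the scatter is therefore expected, giving an estimated 1.1-fold lower number from compound 1 to compound 4 (0.04 log units; within the scatter). Compound 4 is expected to give about 62000 nM, with a likely range from 30000 nM to 125000 nM.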

Compound 4, half-maximal inhibitory concentration: 57800 nM
For compound 4 the middle estimate is 1.1-fold (0.03 log units) above the measured one; the range from low to high includes it.
By their numbers in this assay, from the lowest: compounds 3, 4, 1 and 2 (each within the scatter of the next).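

With 4-chlorophenyl on the carbonyl carbon, the three chlorophenyl compounds and the phenyl compound can now be compared in this assay, and all the new steps stay within the scatter (a 1.2-fold lower number from compound 1 to compound 4 (0.07 log units; within the scatter); a 1.2-fold higher number from compound 3 to compound 4 (0.08 log units; within the scatter); a 1.5-fold lower number from compound 2 to compound 4 (0.18 log units; within the scatter)). Among these compounds, neither the presence of the chloro nor its place on this ring separates the numbers. Nothing available gives a reason for this.

As far as these compounds go, whether an amine or a carboxylic acid on this ring would give a step beyond the scatter remains open.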